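Ring-nitrogen substitution in a rhodanine-type series

The source may hold more compounds than are shown below. What is called first, only, known or untested is meant among the compounds shown, and "the series" means these compounds.

Measured values in an assay for inhibition of LL-diaminopimelate aminotransferase, chloroplastic (Arabidopsis thaliana); a lower number here means a stronger inhibitor, a higher number a weaker inhibitor:
Compound 1 `CC(=O)NN1C(=O)/C(=C/c2ccccc2)SC1=S`: "not active" (no number reported), no number reported.
Compound 2 `CCN1C(=O)/C(=C/c2ccc(OC)cc2)SC1=S`: reaches only a limit of the assay, > 200000 nM.
Compound 3 `COc1ccc(/C=C2\SC(=S)NC2=O)cc1`: 142000 nM.

For the measured compounds named here, compound 3 carries the only number in this assay; one further entry is a limit and one has no number at all. Going by the values given here, the one measured step, an at least 1.4-fold lower number from compound 2 to compound 3 (0.14 log units; that floor lies within the scatter), lies within the scatter, and its floor is set by the limit at which compound 2 sits (the limit of > 200000 nM in this assay, at which 1 of the 3 values shown sits).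

Compound 4 `COc1ccc(/C=C2\SC(=S)N(NC(C)=O)C2=O)cc1` is the next compound to be measured. The change from compound 3 is acetamido in place of hydrogen on an amide-type nitrogen in a ring. Among the compounds with values here, no measured step covers this exact change. Two observations bear on it. Compound 1, which carries the same acetamido group on that nitrogen, gave "not active" (no number reported). Compound 2, with an ethyl group on that nitrogen, reaches only a limit of the assay. Both substituted nitrogens therefore sit at or beyond the weak end of what has been shown, while the unsubstituted compound 3 gives the only number.

Compound 4 is accordingly expected to be weaker than compound 3 in this assay, by roughly a 2.0-fold higher number from compound 3 to compound 4 (0.29 log units; within the scatter), with a real chance that only a limit is reported. The estimate for compound 4 is 280000 nM, within a range of 120000 nM to 700000 nM.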

Compound 4, half-maximal inhibitory concentration: > 200000 nM
Compound 4: no number, only a limit; the forecaster's own chance of this, stated with the estimate: 65%; the middle value does not contradict the limit.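

In this assay compound 4 reaches only a limit, > 200000 nM. Paired directly with the unsubstituted compound, acetamido gives an at least 1.4-fold higher number from compound 3 to compound 4 (0.14 log units; that floor lies within the scatter), so this change on the amide-type nitrogen in a ring brings no gain in this assay, though its true size cannot be stated beyond that floor. The step between the ethyl and acetamido compounds cannot be read, and with compound 2 and compound 4 both stopping at the same limit, hydrogen remains the only group on this nitrogen of the shared core that comes with a number: the limit of > 200000 nM in this assay, at which 2 of the 4 values shown sit.

Still open, as far as these compounds go, is whether a different group on this nitrogen, such as a carboxylic acid on a short chain or a free amine, would return a number in this assay rather than a limit. For the compounds shown here, also open is how far the single number of compound 3, 142000 nM, moves when the methoxy group is exchanged for a hydroxyl group or a halogen, with the amide hydrogen kept in place.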